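A few compounds are considered here, and "the series" means these few. Any claim that something is new, unique, unknown or untested is made for them only; others in the source may bear on it.

Measured so far:
- compound 1 `O=C(O)Cc1sc(C(c2ccccc2)c2ccccc2)nc1-c1ccc(F)cc1`: 77 nM in an in vitro functional assay on HEK285-7 cells for antagonist activity at prostaglandin D2 receptor 2 (Homo sapiens), read by BRET and beta-arrestin recruitment; on this read-out lower numbers stand for stronger inhibition and higher numbers for weaker inhibition
- compound 2 `COc1ccc(OC)c(-c2nc(C(c3ccccc3)c3ccccc3)sc2CC(=O)O)c1`: > 100000 nM in this assay, which is a limit of the assay rather than a number
- compound 3 `O=C(O)Cc1sc(C(c2ccc(F)cc2)c2ccc(F)cc2)nc1-c1cn[nH]c1`: 220 nM in this assay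

All three share one core and differ only in the aromatic group attached to it. Among the numbers shown, compound 3 gives the highest one; compound 1 gives a lower number, and compound 2 gives only a limit. Compound 4 `O=C(O)Cc1sc(C(c2ccc(F)cc2)c2ccc(F)cc2)nc1-c1ccnc(N2CCCC2)c1` has not yet been measured; it differs from compound 3 by 2-(pyrrolidin-1-yl)pyridin-4-yl in place of 1H-pyrazol-4-yl on an aromatic carbon.

For the measured compounds named here, only one measured step changes a group at this same place: an at least 1200-fold higher number from compound 1 to compound 2 (3.11 log units; beyond the scatter). That step shows that swapping the aromatic group here can remove inhibition altogether, compound 2 ending at the limit of > 100000 nM in this assay, at which 1 of the 3 values shown sits. The change from compound 3 to compound 4 brings in a larger group with no hydrogen-bond donor, so a move toward weaker inhibition is expected in this assay, though smaller than that step. The expected step is estimated as a 4.5-fold higher number from compound 3 to compound 4 (0.66 log units; beyond the scatter). Compound 4 is estimated at 1000 nM, with a range from 150 nM to 10000 nM.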

Compound 4, half-maximal inhibitory concentration: > 100000 nM
Compound 4 ended at the assay's limit; the forecaster's own chance of this, stated with the estimate: 15%; middle value at least 100-fold (2.00 log units) from the limit.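

In this assay, 2-(pyrrolidin-1-yl)pyridin-4-yl in place of 1H-pyrazol-4-yl gives an at least 450-fold higher number from compound 3 to compound 4 (2.65 log units; beyond the scatter), so the loss of inhibition seen earlier with 2,5-dimethoxyphenyl is not confined to that one group or to the core of compound 1. It also appears on the core of compound 3, which carries two fluorine atoms. Compound 4 gives a limit of the assay rather than a number, and it is the second compound to do so: the limit of > 100000 nM in this assay, at which 2 of the 4 values shown sit.

The compounds shown do not separate the pyridine ring from the pyrrolidine ring attached to it as the source of this loss. A plain pyridin-4-yl group, or a pyridine bearing a simple amine in place of the pyrrolidine, would tell these two apart.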